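This account rests on a few compounds, and the source may have more. Where it says the series, first, only, none or still open, it means among the compounds named here.

Measured so far:

Compound 1, `COc1cc2ncnc(N3CCc4ccccc43)c2cc1NC(=O)/C=C/C(C)C`, in a functional assay on MCF7 cells (Homo sapiens) for antiproliferative activity, read by MTT assay, with a stated time of 72 h (on this read-out higher numbers stand for weaker inhibition and lower numbers for stronger inhibition), compound 1 gives 6780 nM.
Compound 2, `CCC/C=C/C(=O)Nc1cc2c(N3CCc4ccccc43)ncnc2cc1OC`, in this assay compound 2 gives 3160 nM.
Compound 3, `CC(C)/C=C/C(=O)Nc1cc2c(N3CCCc4ccccc43)ncnc2cc1O[C@@H]1CCOC1`, in this assay compound 3 gives 4680 nM.

Compounds 1 and 2 share one core and differ only in the chain hanging from the amide: propyl in place of isopropyl on a double-bonded chain carbon bound to a double-bonded chain carbon. That single change made a 2.1-fold lower number from compound 1 to compound 2 (0.33 log units; beyond the scatter), a step that lies beyond the scatter of repeated measurements, so it counts as a real, if modest, gain in potency.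

Compound 3 is built on a different core, and the difference between the two cores is not broken down here. Its value in this assay sits close to that of compound 1; the two are within the scatter of each other, so nothing can be said about which is stronger.

Compound 4, `CCC/C=C/C(=O)Nc1cc2c(N3CCCc4ccccc43)ncnc2cc1O[C@@H]1CCOC1`, is compound 3 carrying exactly the change seen between compounds 1 and 2: propyl in place of isopropyl on a double-bonded chain carbon bound to a double-bonded chain carbon. The place of the change reads the same in both pairs, so this is the same change, now on the core of compound 3.

Within the data shown here, since the earlier step is measured, the step from compound 3 to compound 4 is expected to be a 2.0-fold lower number from compound 3 to compound 4 (0.31 log units; beyond the scatter), resting on the one precedent a 2.1-fold lower number from compound 1 to compound 2 (0.33 log units; beyond the scatter). That is a single example, so the expectation carries real uncertainty. Compound 4 is therefore estimated at 2300 nM in this assay, most likely between 1100 nM and 5000 nM.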

Compound 4, half-maximal inhibitory concentration: 4230 nM
The estimate for compound 4 lay 1.8-fold (0.26 log units) below the measured number; the range from low to high includes it.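

Replacing isopropyl with propyl on the core of compound 3 gives a 1.1-fold lower number from compound 3 to compound 4 (0.04 log units; within the scatter) in this assay, so on this core the change has no effect that can be told apart from the ordinary spread of repeated measurements. This looks different from the step on the core of compound 1, which lay beyond the scatter, but the gap between the two steps is itself no larger than two such steps can show by chance: the same change on two cores in this assay, a 2.1-fold lower number (0.33 log units; beyond the scatter) from compound 1 to compound 2 and a 1.1-fold lower number (0.04 log units; within the scatter) from compound 3 to compound 4, 1.9-fold (0.29 log units) apart, within the scatter of two such steps. Among these compounds, the pairs therefore do not show that the core alters the effect of this change, nor do they prove that the effect carries over unchanged, as each core offers only one pair and a real difference between the cores remains possible.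

The compounds shown carry only isopropyl or propyl on a double-bonded chain carbon bound to a double-bonded chain carbon, so it remains open what a longer chain such as pentyl, or a chain ending in an amine, would do there. Also open, on these data alone, is how the change from isopropyl to propyl behaves on any further core, where more pairs could show whether the two cores truly differ.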